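A few compounds are considered here, and "the series" means these few. Any claim that something is new, unique, unknown or untested is made for them only; others in the source may bear on it.

Compound 1 `COc1ccc(C2=C(c3cc(OC)c(OC)c(OC)c3)C(=O)CC2C)cc1C(=O)O`, compound 2 `C=CCOc1cc(C2=C(c3cc(OC)c(OC)c(OC)c3)C(=O)C(O)C2)ccc1OC` and compound 3 `COc1ccc(C2=C(c3cc(OC)c(OC)c(OC)c3)CC(O)C2=O)cc1[N+](=O)[O-]` are close relatives, and all three have been tested in an ADME assay on HEK293 cells (Homo sapiens) for cytotoxicity, read by MTT assay, with a stated time of 72 h (a lower number here means a stronger inhibitor, a higher number a weaker inhibitor), to see how strongly they harm cells. In this assay compound 1 gives > 100 ug/mL as a limit of the assay, not a number. Compound 2 gives > 100 ug/mL as a limit too. Compound 3 gives > 100 ug/mL as a limit as well. Taken together, the limit of > 100 ug/mL in this assay, at which 3 of the 3 values shown sit, is all that the data show so far, so compound 2 stands without a number of its own, in the same place as the other two.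

The next compound to be tested is compound 4 `COc1ccc(C2=C(c3cc(OC)c(OC)c(OC)c3)C(=O)C(O)C2)cc1OC(C)C`, which differs from compound 2 in one place: isopropyl in place of allyl on an oxygen on an aromatic ring, or allyloxy to isopropoxy. The counted difference reads isopropyl in place of allyl on an oxygen on an aromatic ring and is the whole of the change. Among the compounds with values here, no measured pair differs in only one place, so no measured step can serve as a guide. The estimated step that the limit leaves unreadable from compound 2 to compound 4 is expected to stay within the usual scatter, with no direction favoured, and compound 4 will most likely report only a limit. For compound 4 the estimated value is 130 ug/mL with a range from 70 ug/mL to 250 ug/mL expected to hold most repeat measurements.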

Compound 4, half-maximal inhibitory concentration: > 100 ug/mL
Compound 4: only a limit was reported; the forecaster's own chance of this, stated with the estimate: 80%; the middle value lies beyond the limit too.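

In this assay compound 4 gives > 100 ug/mL, which is a limit of the assay and not a number. Within the data shown here, compound 2 also reports only a limit, so no step between compound 2 and compound 4 can be read. The compounds shown leave open how strongly any of them harms cells, because none has a number of its own: the limit of > 100 ug/mL in this assay, at which 4 of the 4 values shown sit.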